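A few compounds are considered here, and "the series" means these few. Any claim that something is new, unique, unknown or untested is made for them only; others in the source may bear on it.

- compound 1 `O[C@H](c1ccccn1)[C@]1(c2cc(C(F)(F)F)ccn2)C[C@H](O)C1` at 50 mL/min/kg
- compound 2 `C[C@]1(O)C[C@@](c2cc(C(F)(F)F)ccn2)([C@H](O)c2ccccn2)C1` at 117 mL/min/kg

In an ADME assay on liver for metabolic stability, with Liver microsome (Rattus norvegicus) as the target, read by LC-MS, using microsomes, with a stated time of 5 h (a lower number here means slower removal, a higher number faster removal of the compound), compound 2 at 117 mL/min/kg stands highest of the two measured compounds, and compound 1 at 50 mL/min/kg lies lower by more than the usual scatter. Compound 3 `O[C@H](c1ccccn1)[C@]1(c2cc(C(F)(F)F)ccn2)C[C@@H](O)C1` has not yet been measured. Its difference from compound 2 is counted as hydrogen in place of methyl on a saturated ring carbon in all, which amounts to hydrogen in place of methyl on a saturated ring carbon. Among the compounds with values here, no measured pair shows this change on its own, so its size in this assay can only be estimated, and with two values in hand the uncertainty is wide. Within the data shown here, the expectation rests on compound 1 at 50 mL/min/kg as the only other reading, and it points toward slower removal. The estimated 2.3-fold lower number from compound 2 to compound 3 (0.35 log units; beyond the scatter) is a fall that would lie beyond the scatter, although a smaller one would not be surprising. For compound 3 the estimated clearance is 52 mL/min/kg with an expected range from 24 mL/min/kg to 110 mL/min/kg as the likely span.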

Compound 3, clearance: 50 mL/min/kg
For compound 3 the middle estimate is 1.0-fold (0.02 log units) above the measured one, and the stated range covers the measured number.
By their numbers in this assay, from the lowest: compounds 1 and 3 (each within the scatter of the next); then compound 2.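

In this assay, within the data shown here, the exchange of methyl for hydrogen on this saturated ring carbon of the four-membered ring now has a reading of its own, which the earlier compounds could not give: a 2.3-fold lower number from compound 2 to compound 3 (0.37 log units; beyond the scatter). The configuration as drawn, by contrast, gives no change at the digits printed from compound 1 to compound 3 (within the scatter), so the two arrangements of the ring substituents in this pair cannot be told apart by this measure, and the reading points to no preference for either: the fact that compounds 1 and 3 differ only in the configuration as drawn Within these three compounds, then, the presence of the methyl is what goes with the higher number, whereas the configuration of the hydrogen-bearing pair leaves the number within the scatter.

From the compounds shown here alone, whether the step from methyl to hydrogen would be the same in the opposite configuration remains open, since methyl appears in only one drawn arrangement, in compound 2. Also open, going by these compounds, is how this ring carbon would respond to a different group in the same place, such as an ethyl group, a fluorine atom or an amine, and whether any of these would lie nearer compound 2 or compound 3.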